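Swapping fluoro for methoxy on a weakly cytotoxic pyrazole

The source may report more compounds than this note shows. Statements on the series, on what has been measured and on what is new or still open speak of the compounds shown alone.

Of the compounds shown here, three sharing one core have been tested in an ADME assay on Huh-7 cells (Homo sapiens) for cytotoxicity, read by XTT assay, with a stated time of 3 days, tested at 200 uM; a higher number here means a weaker effect of the compound at the concentration tested, a lower number a stronger effect. Compound 1 `COc1ccc(-c2cc(-c3ccc4cc(F)ccc4n3)n(-c3ccccc3)n2)cc1` gives 98.9%, and compound 2 `COc1ccc(-c2cc(-c3ccc4cc(F)ccc4n3)n(-c3ccc(F)cc3)n2)cc1` gives 95.4%. For the measured compounds named here, the only single-point step among them, a number 3.5 percentage points lower from compound 1 to compound 2 (within the scatter), changes nothing beyond the scatter. Compound 3 `COc1ccc(-n2nc(-c3ccc(F)cc3)cc2-c2ccc3cc(F)ccc3n2)cc1` stands apart: it gives 52.6%, the lowest of the three numbers, with compound 2 beyond the scatter above it and compound 1 further still.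

Compound 4 `COc1ccc(-c2cc(-c3ccc4cc(F)ccc4n3)n(-c3ccc(OC)cc3)n2)cc1` has not yet been measured in this assay. It differs from compound 3 in one place: methoxy in place of fluoro on an aromatic carbon. Going by the values given here, no measured step covers a methoxy entering for a fluoro, so the size of this step cannot be read from the data directly. Among the compounds with values here, the one step that is known, a number 3.5 percentage points lower from compound 1 to compound 2 (within the scatter), concerns a fluoro on the other six-membered ring and moved the number only within the scatter. Compound 4, however, carries a 4-methoxyphenyl where compound 3 carries a 4-fluorophenyl, and the two compounds with a methoxyphenyl in both positions of that kind, compound 1 and compound 2, both sit high. Compound 4 is therefore expected to move upward, by a number 27.4 percentage points higher from compound 3 to compound 4 (beyond the scatter). The estimated value for compound 4 is 80%, within a range from 50% to 100%.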

Compound 4, a percentage reported as activity, at one concentration (the size of the read-out at that concentration, not a potency): 98.4%
The estimate for compound 4 lay 18.4 percentage points below the measured number; the range from low to high includes it.
By their numbers in this assay, from the lowest: compound 3; then compounds 2, 4 and 1 (each within the scatter of the next).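

In this assay, for the compounds shown here, replacing the 4-fluorophenyl of compound 3 with a 4-methoxyphenyl produces the only single-place step that lies beyond the scatter (a number 45.8 percentage points higher from compound 3 to compound 4 (beyond the scatter)). The same exchange of methoxy for fluoro on the other aromatic ring, where compound 2 carries its fluoro, stays within the scatter (a number 3 percentage points higher from compound 2 to compound 4 (within the scatter)), so in this pair of steps the size of the change depends on which ring carries it. Methoxy in place of hydrogen on that other ring also stays within the scatter (a number 0.5 percentage points lower from compound 1 to compound 4 (within the scatter)), so hydrogen, fluoro and methoxy there give numbers that cannot be told apart, and the low number of the series belongs to compound 3 alone, the only compound with fluoro on its ring.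

From the compounds shown here alone, only fluoro and methoxy are seen at the position that matters, so it remains open whether hydrogen, chloro, an amine or a carboxylic acid there would give a low number or a high one. Nothing measured here explains what makes the fluoro on this ring stand out.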